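The compounds below may be only part of what the source reports. "The series", "measured", "known", "first", "only" and "open" are said of these compounds alone.

Measured in a functional assay on the whole organism for inhibition, with Rattus norvegicus as the target; a higher number here means that more compound is needed for the effect, a lower number that less compound is needed:
compound 1 `CC1CC/C(=N\Nc2ccc(Cl)cc2)c2ncc(C(=O)O)c(=O)n21` gives 0.5 umol/kg
compound 2 `CC1CC/C(=N\Nc2ccc(C(=O)O)cc2)c2ncc(C(=O)O)c(=O)n21` gives 7.6 umol/kg

Among the compounds with values here, of the two compounds measured, compound 2 stands at the higher number, its nearest and only neighbour being compound 1, which sits a long way below it: the single measured step, a 15-fold higher number from compound 1 to compound 2 (1.18 log units; beyond the scatter), is beyond the scatter and is large. Compound 3 `CC(C)c1ccc(N/N=C2\CCC(C)n3c2ncc(C(=O)O)c3=O)cc1` is not yet measured in this assay. It differs from compound 2 in one place (isopropyl in place of carboxy on an aromatic carbon).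

Within the data shown here, only one measured step bears on this change, the one from compound 1 to compound 2, in which the carboxy group arrived in that very position and the number rose steeply. Compound 3 now takes that carboxy away again and puts isopropyl in its place, a group that, like the chloro of compound 1, carries no hydrogen-bond donor or acceptor. Among the measured compounds shown here, the step is therefore expected to run the other way, down to a lower number, with a size of the same order as the one seen between compound 1 and compound 2.

Compound 3 is accordingly estimated at 0.8 umol/kg in this assay, within a range of 0.25 umol/kg to 3 umol/kg, which means an expected step of a 9.5-fold lower number from compound 2 to compound 3 (0.98 log units; beyond the scatter).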

Compound 3, dose for 50% inhibition: 2.4 umol/kg
Estimate against measurement, compound 3: 3.0-fold (0.48 log units) below, and the stated range covers the measured number.
By their numbers in this assay, from the lowest: compound 1; then compound 3; then compound 2.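

In this assay, the new result shows that this position on the aromatic ring does not respond to carboxy alone: putting isopropyl in place of carboxy gives a 3.2-fold lower number from compound 2 to compound 3 (0.50 log units; beyond the scatter), a real drop, but only part of the way back towards the chloro compound. The step of a 4.8-fold higher number from compound 1 to compound 3 (0.68 log units; beyond the scatter) shows that isopropyl, which has 0 hydrogen-bond donors and 0 hydrogen-bond acceptors, still needs more compound than chloro does, so the loss of the donor and acceptor of carboxy does not by itself restore the number of compound 1. Compound 3 therefore sits between the other two, with both of its steps beyond the scatter, and the earlier pair could not show that a group made of carbon only, with the same heavy-atom count as carboxy, also raises the number relative to chloro.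

Nothing given here explains why isopropyl and chloro differ at this position. On these data alone, whether a methyl, a methoxy, an amine or a longer chain here would fall nearer to chloro or nearer to isopropyl remains open, as does whether the order of these groups would hold on another core.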